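Replacing Chloro with Isopropyl on an Inactive Anilide

The source may hold more compounds than are shown below. What is called first, only, known or untested is meant among the compounds shown, and "the series" means these compounds.

Compound 1 `CCOc1nc2c(c(=O)n(C)c(=O)n2C)n1CC(=O)Nc1cccc(Cl)c1` and compound 2 `CCOc1nc2c(c(=O)n(C)c(=O)n2C)n1CC(=O)Nc1ccc(Cl)cc1` share one core and differ as 4-chlorophenyl in place of 3-chlorophenyl on an amide-type nitrogen. In an assay on isolated protein for inhibition of high affinity 3',5'-cyclic-AMP phosphodiesterase 7A (Homo sapiens), read by cAMP accumulation, with a stated time of 10 min (a higher number here means a weaker inhibitor, a lower number a stronger inhibitor), compound 1 gives only a limit, > 200000 nM. Compound 2 likewise gives only a limit, > 200000 nM. The step that the two limits leave unreadable from compound 1 to compound 2 is therefore unreadable, and the limit of > 200000 nM in this assay, at which 2 of the 2 values shown sit, covers both values. Compound 3 `CCOc1nc2c(c(=O)n(C)c(=O)n2C)n1CC(=O)Nc1ccc(C(C)C)cc1` carries isopropyl in place of chloro on an aromatic carbon. Among the measured compounds shown here, no measured step bears on this change, so compound 3 is expected to remain near the limit, with an estimated step of a number no higher from compound 2 to compound 3 (the limit leaves the size open). Compound 3 is expected to give 200000 nM, within 50000 nM to 1000000 nM.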

Compound 3, half-maximal inhibitory concentration: > 200000 nM
Compound 3: only a limit was reported; the forecaster's own chance of this, stated with the estimate: 85%; the middle value lies on the limit itself.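

In this assay compound 3 gives only a limit, > 200000 nM. Among the compounds shown here, no step from compound 1 or compound 2 to compound 3 can be read. The compounds shown leave open whether any substituent on this phenyl group gives a measurable value in this assay.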